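Amide aryl exchange on the shared core: compound 4

The compounds below may be only part of what the source reports. "The series", "measured", "known", "first", "only" and "open" are said of these compounds alone.

Measured so far in a functional assay on HT-29 cells (Homo sapiens) for cytotoxicity, read by MTT assay, with a stated time of 72 h; a higher number here means a weaker inhibitor, a lower number a stronger inhibitor:
compound 1 `O=C(CN1CCN(c2nnc(Cc3ccncc3)c3ccccc23)CC1)Nc1ccc(F)c(F)c1` gives 2320 nM
compound 2 `O=C(CN1CCN(c2nnc(Cc3ccncc3)c3ccccc23)CC1)Nc1cccc(F)c1` gives 6130 nM
compound 3 `Cc1ccc(F)cc1NC(=O)CN1CCN(c2nnc(Cc3ccccc3)c3ccccc23)CC1` gives 171000 nM

Compound 3 has the highest number of the three, and the gap to both others is well beyond the scatter. For the measured compounds named here, the only step measured is a 2.6-fold higher number from compound 1 to compound 2 (0.42 log units; beyond the scatter), a modest change at the amide aryl ring on a core that differs from that of compound 3 in its methylene-linked ring; nothing measured touches the anilide of compound 3 directly.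

Compound 4 `COc1ccc(NC(=O)CN2CCN(c3nnc(Cc4ccccc4)c4ccccc34)CC2)cc1OC` differs from compound 3 by 3,4-dimethoxyphenyl in place of 5-fluoro-2-methylphenyl on an amide-type nitrogen. Going by the values given here, no measured pair shares this change. Among the compounds with values here, the one measured step shows that changing an aromatic fluorine on the anilide moves this assay modestly, so a larger rearrangement of that ring could plausibly move it more, in either direction.

Compound 3 stands far above the other two, so a lower number for compound 4 is expected, a 2.9-fold lower number from compound 3 to compound 4 (0.45 log units; beyond the scatter), with wide uncertainty. The estimate for compound 4 in this assay is 60000 nM, between 10000 nM and 250000 nM.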

Compound 4, half-maximal inhibitory concentration: 145000 nM
The estimate for compound 4 lay 2.4-fold (0.38 log units) below the measured number; the measured number falls inside the stated range.
By their numbers in this assay, from the lowest: compound 1; then compound 2; then compounds 4 and 3 (each within the scatter of the next).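

In this assay the exchange on the amide-type nitrogen gives a 1.2-fold lower number from compound 3 to compound 4 (0.07 log units; within the scatter), so 5-fluoro-2-methylphenyl and 3,4-dimethoxyphenyl cannot be told apart on this core. For the compounds shown here, the two groups differ in substitution, in heavy atoms and in hydrogen-bond acceptors, yet this larger exchange leaves the read-out within the scatter, which the earlier compounds could not show for the core of compound 3. No measurement shown bears on why these two anilides read alike.

As far as these compounds go, whether an aryl ring carrying an amine or a carboxylic acid at this position would separate from these two groups on the same core remains open. Also open, from the compounds shown here alone, is whether 5-fluoro-2-methylphenyl and 3,4-dimethoxyphenyl would still read alike on the core of compound 1.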